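Diaryl urea series: chloro for trifluoromethyl in compound 4

The compounds below may be only part of what the source reports. "The series", "measured", "known", "first", "only" and "open" are said of these compounds alone.

compound 1 `COc1cc2cc(Oc3ccc(NC(=O)Nc4ccccc4)cc3)c(C)nc2cc1OC`: 64.1%
compound 2 `COc1cc2cc(Oc3ccc(NC(=O)Nc4cccc(C(F)(F)F)c4)cc3)c(C)nc2cc1OC`: 15.2%
compound 3 `COc1cc2cc(Oc3ccc(NC(=O)Nc4ccc(Cl)c(C(F)(F)F)c4)cc3)c(C)nc2cc1OC`: 1.27%

In a functional assay on HCT-15 cells (Homo sapiens) for inhibition, read by sulforhodamine B assay, with a stated time of 48 h, tested at 10 uM (a lower number here means a stronger effect, a higher number a weaker effect of the compound at the concentration tested), compound 3 stands lowest of the three, beyond the scatter from compound 2 and far from compound 1. Compound 4 `COc1cc2cc(Oc3ccc(NC(=O)Nc4ccc(Cl)c(Cl)c4)cc3)c(C)nc2cc1OC` differs from compound 3 by chloro in place of trifluoromethyl on an aromatic carbon. Going by the values given here, no measured pair swaps chloro for trifluoromethyl directly. Among the compounds with values here, the steps that bear on it are a number 48.9 percentage points lower from compound 1 to compound 2 (beyond the scatter), where trifluoromethyl enters, and a number 13.9 percentage points lower from compound 2 to compound 3 (beyond the scatter), where chloro enters; together they give a number 62.8 percentage points lower from compound 1 to compound 3 (beyond the scatter). Chloro on its own is unmeasured here, so the expectation for compound 4 is a small step upward, possibly within the scatter, as a number 4.7 percentage points higher from compound 3 to compound 4 (within the scatter). Compound 4 is therefore estimated at 6% in this assay, with a range from 0.5% to 25%.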

Compound 4, a percentage reported as activity, at one concentration (the size of the read-out at that concentration, not a potency): 18.9%
Beside the measured number, compound 4's estimate is 12.9 percentage points below it, and the stated range covers the measured number.
By their numbers in this assay, from the lowest: compound 3; then compounds 2 and 4 (each within the scatter of the next); then compound 1.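

In this assay, chloro does not replace trifluoromethyl at this position, ortho to a chloro group, without loss: a number 17.6 percentage points higher from compound 3 to compound 4 (beyond the scatter). With no chloro on the ring, 3,4-dichlorophenyl and 3-(trifluoromethyl)phenyl cannot be told apart, a number 3.7 percentage points higher from compound 2 to compound 4 (within the scatter), and 3,4-dichlorophenyl still holds a large gain over phenyl, a number 45.2 percentage points lower from compound 1 to compound 4 (beyond the scatter). Nothing available here explains the step at this position.

Still open, as far as these compounds go, is how a nitrile or an amine would read at this position, and how a single chloro on this ring would read.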